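The source may hold more compounds than are shown below. What is called first, only, known or untested is meant among the compounds shown, and "the series" means these compounds.

Measured so far in an ADME assay on cells (Peritoneal macrophage cell, Mus musculus) for cytotoxicity, read by fluorescence and resazurin assay, with a stated time of 3 days; a lower number here means that less compound is tolerated, a higher number that more compound is tolerated:

compound 1 `O=C(Nc1cc(-c2ccccn2)n[nH]1)N1CCC(c2ccc(Cl)cc2)CC1`: > 55000 nM
compound 2 `O=C(NCc1ccccc1)Nc1[nH]nc(-c2ccccn2)c1Cl`: > 64000 nM
compound 3 `COc1ccc(C(=O)Nc2cc(-c3ccccn3)n[nH]2)cc1`: > 40300 nM

Each of these three values is a limit of the assay, not a number. Compound 1 stands at the limit of > 55000 nM in this assay, at which 1 of the 3 values shown sits. Compound 2 sits at the limit of > 64000 nM in this assay, at which 1 of the 3 values shown sits. Compound 3 sits at the limit of > 40300 nM in this assay, at which 1 of the 3 values shown sits. Among the measured compounds shown here, since every value is a limit, no compound can be placed above or below another; all three are tolerated up to the highest concentration tested.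

Compound 4 `O=C(Nc1cc(-c2ccccn2)n[nH]1)N1CCC(c2ccccc2)CC1` differs from compound 1 in one place: hydrogen in place of chloro on an aromatic carbon. For the measured compounds named here, no measured step between any two of the compounds shows the effect of this change, so the expected step from compound 1 to compound 4 is none beyond the scatter, a number no higher from compound 1 to compound 4 (the limit leaves the size open). Compound 4 is therefore expected to reach 55000 nM, with a range from 25000 nM to 120000 nM, most likely again reported only as a limit.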

Compound 4, half-maximal cytotoxic concentration: > 64000 nM
Compound 4 was reported as a limit (the forecaster's own chance of this, stated with the estimate: 80%); middle value at least 1.1-fold (0.06 log units) away from the limit.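

Compound 1 and compound 4 are both reported only as limits, not numbers, and the step between them cannot be read. The compounds shown leave open at what concentration any of them harms the cells.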